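The source may hold more compounds than are shown below. What is called first, only, known or untested is meant among the compounds shown, and "the series" means these compounds.

In an assay on frontal cortex for displacement of a labelled ligand from corticotropin-releasing factor receptor 1 (Rattus norvegicus), with a stated time of 2 h (a lower number here means a stronger inhibitor, a higher number a weaker inhibitor), compound 1 `COc1nc(C)c(Nc2nc(Cl)cn([C@H](COC(=O)c3ccccc3)C3CC3)c2=O)cc1C` gives 1.5 nM. Compound 2 `COc1nc(C)c(Nc2nc(Cl)cn([C@H](COC(=O)Nc3ccc(Cl)cc3Cl)C3CC3)c2=O)cc1C` gives 1.7 nM, and compound 3 `COc1nc(C)c(Nc2nc(Cl)cn([C@H](COc3ccccn3)C3CC3)c2=O)cc1C` gives 1.2 nM. Compound 1 holds the second highest of these three numbers, yet all three sit within the scatter of one another: a 1.1-fold higher number from compound 1 to compound 2 (0.05 log units; within the scatter) and a 1.3-fold lower number from compound 1 to compound 3 (0.10 log units; within the scatter) are both small. Compound 4 `COc1nc(C)c(Nc2nc(Cl)cn([C@H](COc3ccc(C(F)(F)F)cn3)C3CC3)c2=O)cc1C` differs from compound 1 in one place: 5-(trifluoromethyl)pyridin-2-yl in place of benzoyl on an oxygen on a saturated carbon. Among the measured compounds shown here, the measured step that bears most directly on this change is the one from compound 1 to compound 3, where a pyridin-2-yl takes the place of the benzoyl on the same oxygen; the related change a 1.4-fold lower number from compound 2 to compound 3 (0.15 log units; within the scatter) is of like size. For the measured compounds named here, both stayed within the scatter, and the data contain no compound that separates a trifluoromethyl-bearing pyridin-2-yl from the plain one. Compound 4 is therefore expected to give 1.2 nM, with a range from 0.5 nM to 3 nM. The estimated step of a 1.3-fold lower number from compound 1 to compound 4 (0.10 log units; within the scatter) is expected to remain within the scatter.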

Compound 4, half-maximal inhibitory concentration: 1.6 nM
The estimate for compound 4 lay 1.3-fold (0.12 log units) below the measured number; low and high end bracket the measured number.
By their numbers in this assay, from the lowest: compounds 3, 1, 4 and 2 (each within the scatter of the next).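

In this assay, trifluoromethyl in place of hydrogen on an aromatic carbon gives a 1.3-fold higher number from compound 3 to compound 4 (0.12 log units; within the scatter), so the pyridin-2-yl on this oxygen carries that substituent without a shift beyond the scatter. Set against the benzoyl, the 5-(trifluoromethyl)pyridin-2-yl gives a 1.1-fold higher number from compound 1 to compound 4 (0.03 log units; within the scatter), and set against the (2,4-dichlorophenyl)carbamoyl it gives a 1.1-fold lower number from compound 2 to compound 4 (0.03 log units; within the scatter), so all four groups at this place remain within the scatter of one another. Nothing given here explains why these numbers stay so close. The compounds leave open whether a group without an aromatic ring at this place, such as a free hydroxyl, a short alkyl chain or an amine, would keep the number. They also leave open whether fluorine or a nitrile on the pyridin-2-yl would read the same.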